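A few compounds are considered here, and "the series" means these few. Any claim that something is new, unique, unknown or untested is made for them only; others in the source may bear on it.

Measured so far in a functional assay on HeLa cells (Homo sapiens) for antiproliferative activity, read by MTT assay, with a stated time of 48 h (a higher number here means a weaker inhibitor of growth, a lower number a stronger inhibitor of growth), are two compounds.

Compound 1 `COC(=O)N1N=C(c2cccc(O)c2)CC1c1cc(OC)c(OC)c(OC)c1` gives 1970 nM
Compound 2 `COC(=O)N1N=C(c2cccc(C)c2)CC1c1cc(OC)c(OC)c(OC)c1` gives 50 nM

Compound 2 at 50 nM holds the lower of the two numbers, and its gap to compound 1 lies beyond the scatter. The change to compound 3 `COC(=O)N1N=C(c2cccc(Cl)c2)CC1c1cc(OC)c(OC)c(OC)c1` is chloro in place of methyl on an aromatic carbon and reads 3-methylphenyl to 3-chlorophenyl, with chloro in place of methyl on an aromatic carbon, meta to a large group. For the measured compounds named here, only one measured step bears on it. This is a 39-fold lower number from compound 1 to compound 2 (1.60 log units; beyond the scatter) and it is large, with methyl in place of hydroxy on an aromatic carbon. Going by the values given here, that step shows that a swap of this kind can move the number strongly, but it involves hydroxy, and no chloro compound has been measured. The estimated step of a 1.6-fold higher number from compound 2 to compound 3 (0.20 log units; within the scatter) is small, toward a higher number, and expected to stay within the scatter. For compound 3 the estimated value is 80 nM within an expected range of 25 nM to 300 nM.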

Compound 3, concentration for 50% growth inhibition: 160 nM
Compound 3: middle estimate off by 2.0-fold (0.30 log units), on the low side, within the range that was stated.
By their numbers in this assay, from the lowest: compound 2; then compound 3; then compound 1.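

In this assay, the chloro for methyl swap on this aromatic carbon, meta to a large group, is not neutral: the number rises beyond the scatter (a 3.2-fold higher number from compound 2 to compound 3 (0.51 log units; beyond the scatter)), so the two groups are not interchangeable here. Chloro still stays far from hydroxy (a 12-fold lower number from compound 1 to compound 3 (1.09 log units; beyond the scatter)), which shows that the large gain seen with methyl is not unique to methyl and gives the order methyl, chloro, hydroxy across these three compounds. No measurement at hand accounts for this order.

Still open, as far as these compounds go, is where an amine, a methoxy group or a carboxylic acid at this position would fall relative to these three groups. Also open, from the compounds shown here alone, is whether the same order would hold with these groups elsewhere on that ring.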